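Cyclohexylmethyl in place of 4-methoxybenzyl on compound 3

The source may report more compounds than this note shows. Statements on the series, on what has been measured and on what is new or still open speak of the compounds shown alone.

Measured in a functional assay on MV4-11 cells (Homo sapiens) for antiproliferative activity, read by luminescence and CellTiter-Glo, with a stated time of 72 h; on this read-out higher numbers stand for weaker inhibition and lower numbers for stronger inhibition
- compound 1 `Cc1noc(C)c1-c1ccc2c(Nc3ccc(F)cc3)nn(C3CCCCO3)c2c1` gives 9900 nM
- compound 2 `COc1ccc(Nc2nn(Cc3ccc(C)cc3)c3cc(-c4c(C)noc4C)ccc23)cc1` gives 11900 nM
- compound 3 `CNc1cc(-c2ccc3cnn(Cc4ccc(OC)cc4)c3c2)cn(C)c1=O` gives 2700 nM

Compound 3 holds the lowest of the three numbers, and compound 1 and compound 2 both lie beyond the scatter above it. Compound 4 `CNc1cc(-c2ccc3cnn(CC4CCCCC4)c3c2)cn(C)c1=O` differs from compound 3 as follows: cyclohexyl in place of 4-methoxyphenyl on a saturated chain carbon bound to an aromatic nitrogen. For the measured compounds named here, no measured pair isolates this change, so the expectation in this assay is only a modest move toward a higher number, possibly within the scatter. The expected step runs a 1.5-fold higher number from compound 3 to compound 4 (0.17 log units; within the scatter) in this estimate. For compound 4 the estimated value is 4000 nM, with an expected range of 1500 nM to 11000 nM.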

Compound 4, half-maximal inhibitory concentration: 2690 nM
The estimate for compound 4 lay 1.5-fold (0.17 log units) above the measured number; the measured number falls inside the stated range.
By their numbers in this assay, from the lowest: compounds 4 and 3 (each within the scatter of the next); then compounds 1 and 2 (each within the scatter of the next).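

In this assay cyclohexyl in place of 4-methoxyphenyl on a saturated chain carbon bound to an aromatic nitrogen gives a 1.0-fold lower number from compound 3 to compound 4 (0.00 log units; within the scatter) as the step. For the compounds shown here, for this pair, neither the aromatic ring nor the hydrogen-bond acceptor of 4-methoxyphenyl is needed to keep the number; the earlier compounds offered no pair isolating this position. Nothing at hand explains this flat step. Still open, going by these compounds, is whether a longer chain to the cyclohexyl, or an amine or carboxylic acid on it, moves the number beyond the scatter.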